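Efficacy notes across the shared-core series

The source may hold more compounds than are shown below. What is called first, only, known or untested is meant among the compounds shown, and "the series" means these compounds.

Three compounds have been run in an assay on isolated protein for agonist activity at Bile acid receptor (Homo sapiens), read by FRET; a lower number here means a smaller maximal response, a higher number a larger maximal response. Compound 1 `Cc1cc(OCc2c(-c3c(Cl)cccc3Cl)noc2C(C)C)ncc1[N+](=O)[O-]` gives 101% in this assay. Compound 2 `Cc1cc(OCc2c(-c3c(Cl)cccc3Cl)noc2C(C)C)nc2ccccc12` gives 104%. Compound 3 `CC(Nc1ccc(C(=O)O)cc1)c1ccc(OCc2c(-c3c(Cl)cccc3Cl)noc2C2CC2)nc1C(F)(F)F` gives 99%, nominally the lowest of the three numbers, yet its gap to compound 1 and its gap to compound 2 both lie within the usual scatter, so the three cannot be ranked on these figures. Each of them reaches roughly the full response of the reference.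

Compound 4 `CC(Oc1cccc(C(=O)O)c1)c1ccc(OCc2c(-c3c(Cl)cccc3Cl)noc2C2CC2)nc1C(F)(F)F` is not yet measured. It differs from compound 3 by 3-carboxyphenoxy in place of (4-carboxyphenyl)amino on a saturated chain carbon bound to an aromatic carbon and a saturated chain carbon. Within the data shown here, no step between two measured compounds isolates a change of this kind, so there is no measured precedent for it. Compound 1, compound 2 and compound 3 all give near-full maximal response while differing widely elsewhere in their structures. On that basis the step from compound 3 to compound 4 is expected to be small, a number 4 percentage points lower from compound 3 to compound 4 (within the scatter), with no direction favoured beyond the scatter. Compound 4 is accordingly estimated at 95% in this assay, within an expected range of 75% to 110%.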

Compound 4, largest response reached (reported as efficacy), in percent of the reference or control that the assay uses: 102%
Estimate against measurement, compound 4: 7 percentage points below; the range from low to high includes it.
By their numbers in this assay, from the lowest: compounds 3, 1, 4 and 2 (each within the scatter of the next).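

In this assay, among these compounds, 3-carboxyphenoxy in place of (4-carboxyphenyl)amino on a saturated chain carbon bound to an aromatic carbon and a saturated chain carbon gives a number 3 percentage points higher from compound 3 to compound 4 (within the scatter), the first step that isolates a single place. This one exchange alters both the linking atom and the named position of the carboxy group, and the maximal response stays near full through the two together, so neither alteration is resolved alone. No measurement shown accounts for this outcome.

As far as these compounds go, whether 4-carboxyphenoxy or (3-carboxyphenyl)amino would behave in the same way remains open, and those two groups would separate the linking atom from the carboxy placement. Also open, from the compounds shown here alone, is whether an unsubstituted phenoxy group, without the carboxylic acid, would hold the response at this carbon.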